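The source may hold more compounds than are shown below. What is called first, only, known or untested is meant among the compounds shown, and "the series" means these compounds.

Working notes on the series, read in a functional assay on NCI-H460 cells (Homo sapiens) for inhibition, read by MTT assay, with a stated time of 24 h, tested at 1 ug/mL (a lower number here means less inhibition of growth, a higher number more inhibition of growth at the concentration tested), as the sole read-out. Compound 1 (`O=C(O)CCCCC(CCSC(=O)c1ccccc1)SC(=O)c1ccccc1`) gives 0.77% and compound 2 (`CC(=O)SCCC(CCCCC(=O)Nc1cccc(Cl)c1)SC(C)=O`) gives 0.31% in this measurement. Among the measured compounds shown here, these two values lie within the scatter of each other, so compound 1 stands level with the only other measured compound, and both show very little inhibition of growth at the concentration tested.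

The next entry is compound 3 (`O=C(CCCCC(CCSC(=O)c1ccccc1)SC(=O)c1ccccc1)Nc1ccc(Cl)cc1`), which differs from compound 1 at the acid end ((4-chlorophenyl)amino in place of hydroxy on a carbonyl carbon). Here (4-chlorophenyl)amino stands in place of hydroxy on a carbonyl carbon, so carboxy becomes (4-chlorophenyl)carbamoyl. For the measured compounds named here, no measured pair shows this change, so its size can only be judged from the low values of compound 1 at 0.77% and compound 2 at 0.31% in this assay alone. The estimated step of a number 2.2 percentage points higher from compound 1 to compound 3 (within the scatter) is small and upward, and it is expected to stay within the scatter. For compound 3 the estimated value is 3% with an expected range from 0% to 12% in this measurement.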

Compound 3, percent growth inhibition at one concentration: 9.8%
Beside the measured number, compound 3's estimate is 6.8 percentage points below it; the measured number falls inside the stated range.
By their numbers in this assay, from the lowest: compounds 2, 1 and 3 (each within the scatter of the next).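

Among the compounds shown here, at the acid end, (4-chlorophenyl)amino in place of hydroxy on a carbonyl carbon gives the first readable step, a number 9 percentage points higher from compound 1 to compound 3 (within the scatter), in this assay. Carboxy can therefore give way to (4-chlorophenyl)carbamoyl, which brings in a six-membered aromatic ring of carbon only, with no change that stands clear of the scatter, so this single step neither shows the free carboxylic acid to be needed for the level seen here nor shows a gain from the added ring. No measurement at hand bears on the reason for this result.

Going by these compounds, all three values lie within the scatter of their neighbours in the ranking, so it stays open whether any group on this carbonyl carbon, such as a methyl ester or a morpholine amide, would move growth inhibition clear of the scatter. Also open, on these data alone, is whether a longer saturated chain on the same carbonyl carbon, or free thiols in place of the two benzoyl thioesters on the shared core of compound 1, would change the picture.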